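Exchanging One Aryl Group on a Shared Core

This account rests on a few compounds, and the source may have more. Where it says the series, first, only, none or still open, it means among the compounds named here.

In a functional assay on MDA-MB-231 cells (Homo sapiens) for inhibition, read by MTT assay, with a stated time of 48 h (on this read-out lower numbers stand for stronger inhibition and higher numbers for weaker inhibition), compound 1 (`COc1cc(-c2cc(-c3cccc([N+](=O)[O-])c3)nc(-c3ccccc3)n2)cc(OC)c1OC`) gives 2440 nM and compound 2 (`COc1ccc(-c2cc(-c3cc(OC)c(OC)c(OC)c3)nc(-c3ccccc3)n2)c(OC)c1`) gives 1440 nM. Going by the values given here, these two numbers lie within the usual scatter of each other, so compound 2 stands level with its only measured neighbour. Compound 3 (`COc1cc(-c2cc(-c3cccc(O)c3)nc(-c3ccccc3)n2)cc(OC)c1OC`) carries 3-hydroxyphenyl in place of 2,4-dimethoxyphenyl on an aromatic carbon. Among the compounds with values here, one measured step bears on this change, and it concerns the same carbon: a 1.7-fold lower number from compound 1 to compound 2 (0.23 log units; within the scatter). That exchange of 3-nitrophenyl for 2,4-dimethoxyphenyl stayed within the scatter. Within the data shown here, a single step is thin evidence, and no measured compound yet carries 3-hydroxyphenyl, but no shift beyond the scatter is expected in this assay. The step expected is a 1.2-fold higher number from compound 2 to compound 3 (0.07 log units; within the scatter). For compound 3, the estimate is 1700 nM, with an expected range of 500 nM to 6000 nM.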

Compound 3, half-maximal inhibitory concentration: 1990 nM
Beside the measured number, compound 3's estimate is 1.2-fold (0.07 log units) below it; the range from low to high includes it.
By their numbers in this assay, from the lowest: compounds 2, 3 and 1 (each within the scatter of the next).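

In this assay, this carbon now carries a third aryl group, and the number again stays level: a 1.4-fold higher number from compound 2 to compound 3 (0.14 log units; within the scatter), and a 1.2-fold lower number from compound 1 to compound 3 (0.09 log units; within the scatter). The second step is the smallest exchange so far, hydroxy in place of nitro, and the first step holds within the scatter even though 3-hydroxyphenyl has 1 hydrogen-bond donor and 2,4-dimethoxyphenyl has 0, so this read-out does not separate these three aryl groups. No measurement on hand explains why these exchanges leave the number in place.

On these data alone, whether this carbon accepts every group equally remains open. A phenyl ring bearing an amine or a carboxylic acid, or a saturated alkyl chain in place of the aryl ring, could still shift the number beyond the scatter.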